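A few compounds are considered here, and "the series" means these few. Any claim that something is new, unique, unknown or untested is made for them only; others in the source may bear on it.

Two arylsulfonyl hydrazides have been tested so far. In an assay for inhibition of Indoleamine 2,3-dioxygenase 1 (Homo sapiens), read by spectrophotometry, with stated times of 1 h and 4 h (a lower number here means a stronger inhibitor, a higher number a weaker inhibitor), compound 1 `CC(=O)Nc1ccc(S(=O)(=O)NNc2ccc(Cl)c(Cl)c2)cc1` gives 247 nM, and in this assay compound 2 `O=S(=O)(NNc1ccc(Br)cc1)c1ccccc1` gives 172 nM. Compound 2 carries the lowest of the two numbers, but its nearest neighbour is compound 1, whose number is within the scatter of repeated measurements, so the two cannot be told apart on these data.

The next compound, compound 3 `O=C(O)CCc1ccc(S(=O)(=O)NNc2ccc(Br)cc2)cc1`, differs from compound 2 in a single place: 2-carboxyethyl in place of hydrogen on an aromatic carbon. For the measured compounds named here, no measured pair yet shows what such a change does here. Since compound 1 carries a group in the same place and still lands close to compound 2, the 2-carboxyethyl chain is expected to change the number only modestly, if at all, with the step from compound 2 to compound 3 estimated as a 1.7-fold higher number from compound 2 to compound 3 (0.24 log units; within the scatter). Compound 3 is therefore expected to give about 300 nM, with a range from 100 nM to 1000 nM.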

Compound 3, half-maximal inhibitory concentration: 141 nM
Compound 3: middle estimate off by 2.1-fold (0.33 log units), on the high side, and the stated range covers the measured number.
By their numbers in this assay, from the lowest: compounds 3, 2 and 1 (each within the scatter of the next).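

For the compounds shown here, this is the first measured pair for this position: in this assay, putting 2-carboxyethyl in place of hydrogen on the aromatic carbon para to a large group gives a 1.2-fold lower number from compound 2 to compound 3 (0.09 log units; within the scatter) and so leaves compound 2 and compound 3 indistinguishable. The position therefore takes this whole chain, with its carbonyl and its hydrogen-bond donor, without any change that can be read from these numbers. No separate measurement bears on the reason for this result.

The compounds shown leave open whether a carboxylic acid placed directly on the ring, an amine or a longer chain in the same place would also leave the number unchanged. As far as these compounds go, one added group on the core of compound 2 shows no trend, so how much more this position can carry remains unknown.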